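The source may report more compounds than this note shows. Statements on the series, on what has been measured and on what is new or still open speak of the compounds shown alone.

Measured so far in a functional assay on a cell-free system (Platelet, plasma, Homo sapiens) for inhibition; on this read-out lower numbers stand for stronger inhibition and higher numbers for weaker inhibition:
compound 1 `O=C(O)CCN1Cc2ccc(NC(=O)c3ccc(C4CCNCC4)cc3)cc2C1=O` gives 9600 nM;
compound 2 `CC(CC(=O)O)N1Cc2ccc(NC(=O)CC3CCNCC3)cc2C1=O` gives 2700 nM;
compound 3 `CC(CC(=O)O)N1Cc2ccc(NC(=O)CCCC3CCNCC3)cc2C1=O` gives 5400 nM.

Compound 3 sits second highest of the three numbers in this assay. Its nearest neighbour is compound 1, and compound 2 lies furthest, yet both gaps fall within the scatter, so no order among the three can be claimed. Going by the values given here, the one measured step, a 2.0-fold higher number from compound 2 to compound 3 (0.30 log units; within the scatter), also stays within the scatter.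

Compound 4 `O=C(O)CN1Cc2ccc(NC(=O)CCCC3CCNCC3)cc2C1=O` is made from compound 3 by carboxymethyl in place of 1-(carboxymethyl)ethyl on an amide-type nitrogen in a ring. Among the compounds with values here, no measured step touches this position, so nothing in the data sets a direction. Compound 4 is expected to give 8000 nM, between 2500 nM and 25000 nM, an estimated step of a 1.5-fold higher number from compound 3 to compound 4 (0.17 log units; within the scatter) that may stay within the scatter.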

Compound 4, half-maximal inhibitory concentration: 66000 nM
Compound 4: the middle estimate sits 8.3-fold (0.92 log units) below what was measured; the measured number lies above the stated range.
By their numbers in this assay, from the lowest: compounds 2, 3 and 1 (each within the scatter of the next, the first and the last beyond it); then compound 4.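

In this assay, going by these compounds alone, the group on the amide-type nitrogen in a ring carries real weight: a 12-fold higher number from compound 3 to compound 4 (1.09 log units; beyond the scatter) follows from carboxymethyl replacing 1-(carboxymethyl)ethyl, whereas the one earlier step stayed within the scatter. The smaller carboxymethyl group therefore gives much weaker inhibition on this core. Nothing measured here gives a reason for this loss.

Still open, going by these compounds, is whether a 3-carboxypropyl group or a methyl ester on this nitrogen would keep the number near that of compound 3. The same change on the shorter chain of compound 2 also remains untested in the compounds shown.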